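This account rests on a few compounds, and the source may have more. Where it says the series, first, only, none or still open, it means among the compounds named here.

In a functional assay on HCT-116 cells (Homo sapiens) for antiproliferative activity, read by MTT assay, with a stated time of 24 h (a higher number here means a weaker inhibitor, a lower number a stronger inhibitor), compound 1 `COc1ccc(C(=O)/C=C/c2cc(OC)c(OC)c(OC)c2)c2c1C=CC(C)(C)O2` gives 7650 nM. Compound 2 `COc1ccc(/C=C/C(=O)c2ccc(OC)c3c2OC(C)(C)C=C3)c(F)c1`, which carries a 2-fluoro-4-methoxyphenyl on a double-bonded chain carbon bound to a double-bonded chain carbon, reaches only a limit of the assay in this assay, > 10000 nM. Compound 3 `COc1ccc(C(=O)/C=C/c2ccc(Br)cc2)c2c1C=CC(C)(C)O2` likewise stops at a limit in this assay, > 10000 nM. The step that the two limits leave unreadable from compound 2 to compound 3 therefore cannot be sized, because both of its ends sit at the limit of > 10000 nM in this assay, at which 2 of the 3 values shown sit. Compound 2 thus stands at a limit rather than at a number, and one further value of the three shown is a limit as well.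

Compound 4 `COc1ccc(C(=O)/C=C/c2cc(Cl)ccc2O)c2c1C=CC(C)(C)O2` differs from compound 2 in one place: 5-chloro-2-hydroxyphenyl in place of 2-fluoro-4-methoxyphenyl on a double-bonded chain carbon bound to a double-bonded chain carbon. For the measured compounds named here, the only measured exchange of the ring at this place is the unreadable one, so no sized step guides the expectation, and the two limits suggest that a ring change here tends to leave a weak inhibitor. Compound 4 is therefore estimated to sit near 9000 nM, between 3000 nM and 30000 nM. The implied step an at least 1.1-fold lower number from compound 2 to compound 4 (0.04 log units; that floor lies within the scatter) is expected to be read only against a limit.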

Compound 4, half-maximal inhibitory concentration: 5240 nM
Compound 4: the middle estimate sits 1.7-fold (0.23 log units) above what was measured; the range from low to high includes it.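

On a double-bonded chain carbon bound to a double-bonded chain carbon, a ring exchange now gives a number rather than a limit: in this assay compound 4, with its 5-chloro-2-hydroxyphenyl, gives 5240 nM. Going by these compounds, the change is an at least 1.9-fold lower number from compound 2 to compound 4 (0.28 log units; that floor lies within the scatter) and an at least 1.9-fold lower number from compound 3 to compound 4 (0.28 log units; that floor lies within the scatter), so the true size of each step stays unknown, and neither floor shows a change beyond the usual scatter. Compound 2 and compound 3 each stop at a limit of the assay, not at a number: the limit of > 10000 nM in this assay, at which 2 of the 4 values shown sit.

The chlorine and the hydroxyl enter together, and the compounds shown cannot tell which of them, if either, matters to the value. Also open, on these data alone, is what a phenyl ring carrying an amine or a carboxylic acid would give at this place.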